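This account rests on a few compounds, and the source may have more. Where it says the series, first, only, none or still open, it means among the compounds named here.

Compound 1 `C=C1C[C@]23C[C@@]1(O)CC[C@@H]2c1cccc(C)c1[C@@H]3Cn1cc(-c2ccc(C)cc2)nn1`: in a functional assay on MCF7 cells (Homo sapiens) for cytotoxicity, read by MTT assay, with a stated time of 4 days (a lower number here means a stronger inhibitor, a higher number a weaker inhibitor), compound 1 gives > 20000 nM, which is a limit of the assay rather than a number.
Compound 2 `C=C1C[C@]23C[C@@]1(O)CC[C@H]2c1cc(Br)c(O)c(C)c1[C@@H]3Cn1cc(-c2ccccn2)nn1`: in this assay compound 2 gives > 20000 nM, again only a limit.

Compound 2 thus stands at the limit of > 20000 nM in this assay, at which 2 of the 2 values shown sit, and no real number places it against compound 1. Compound 3 `C=C1C[C@]23C[C@@]1(O)CC[C@H]2c1cc(Br)c(O)c(C)c1[C@@H]3Cn1cc(-c2ccc(Cl)cc2)nn1` differs from compound 2 by 4-chlorophenyl in place of pyridin-2-yl on an aromatic carbon. For the measured compounds named here, no step between measured compounds is known, so nothing shows what such a change does here. Compound 3 is expected to stay at the limit, with an expected step that the limit leaves unreadable from compound 2 to compound 3, no shift beyond the scatter, because of the limit of > 20000 nM in this assay, at which 2 of the 2 values shown sit. The estimate for compound 3 is 30000 nM, within 8000 nM to 100000 nM.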

Compound 3, half-maximal inhibitory concentration: 10200 nM
The estimate for compound 3 lay 2.9-fold (0.47 log units) above the measured number; the measured number falls inside the stated range.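

In this assay, putting 4-chlorophenyl in place of pyridin-2-yl at this place on the five-membered ring gives an at least 1.9-fold lower number from compound 2 to compound 3 (0.29 log units; that floor lies within the scatter). This shared core therefore now has a real number, with compound 3 at 10200 nM. The true size of the step stays hidden because compound 2 holds only a limit: the limit of > 20000 nM in this assay, at which 2 of the 3 values shown sit.

Going by these compounds, whether the chlorine or the carbon-only ring matters more remains open. So does what an amine or a carboxylic acid would do at this place.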